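This account rests on a few compounds, and the source may have more. Where it says the series, first, only, none or still open, it means among the compounds named here.

Going by the values given here, compound 2 `O=S(=O)(Nc1cccc2cccnc12)c1cccs1` pairs a thiophen-2-yl sulfonamide with the shared core, and in an assay on OCI-Ly3 cells for activation of NF-kappa-B inhibitor alpha (Homo sapiens), read by a luciferase reporter (on this read-out higher numbers stand for an effect only at larger amounts of compound and lower numbers for an effect already at smaller amounts), compound 2 gives 5300 nM, which is the only number reported across this small set. The other member, compound 1 `COc1ccc(S(=O)(=O)Nc2cccc3ccc(C)nc23)c([N+](=O)[O-])c1`, shows "not determined" (no result reported) in this assay, so compound 2 stands alone as the reference point. Compound 3 `O=S(=O)(Nc1cccc2cccnc12)c1ccc(Cl)s1` differs from compound 2 in a single place: chloro in place of hydrogen on an aromatic carbon. Among the compounds with values here, no step between two measured compounds exists to show how such a change behaves on this read-out, so the expectation rests on the structural change alone. The step is expected to be small, toward slightly lower concentration, a 1.8-fold lower number from compound 2 to compound 3 (0.25 log units; within the scatter), and it may not exceed the usual scatter. The estimate for compound 3 in this assay is 3000 nM, with a range from 1000 nM to 10000 nM.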

Compound 3, half-maximal effective concentration: 2700 nM
Estimate against measurement, compound 3: 1.1-fold (0.05 log units) above; the range from low to high includes it.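

Going by these compounds alone, the step from thiophen-2-yl to 5-chlorothiophen-2-yl gives the first reading for this position in this assay, namely a 2.0-fold lower number from compound 2 to compound 3 (0.29 log units; within the scatter). A chlorine on this aromatic carbon next to the ring sulfur therefore keeps the compound active on this read-out, and compound 2 and compound 3 cannot be told apart, so this one change shows no real gain or loss. Nothing shown offers an explanation of how the two values relate.

As far as these compounds go, it remains open whether a methyl, a methoxy, an amine or a carboxylic acid at this same place would move the number beyond the usual scatter. With only hydrogen and chloro shown here, it is also open whether any substituent on this carbon matters to the read-out at all.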